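This account rests on a few compounds, and the source may have more. Where it says the series, first, only, none or still open, it means among the compounds named here.

Compound 2 `COc1ccc(-c2nc3cccc(-c4cc(OC)c(OC)c(OC)c4)c3o2)cc1` gives 3500 nM in a functional assay on NCI-H460 cells (Homo sapiens) for antiproliferative activity, read by MTT assay, with a stated time of 48 h; on this read-out lower numbers stand for stronger inhibition and higher numbers for weaker inhibition. Among the numbers in hand it stands lowest, though its nearest neighbour, compound 1 `COc1cc(-c2cccc3nc(-c4ccccc4)oc23)cc(OC)c1OC`, gives 6800 nM in this assay, and the step of a 1.9-fold lower number from compound 1 to compound 2 (0.29 log units; within the scatter) is within the scatter. Compound 3 `COc1cc(-c2cccc3nc(-c4cccc(C)c4)oc23)cc(OC)c1OC` is reported in this assay only as a limit, > 25000 nM. That limit of > 25000 nM in this assay, at which 1 of the 3 values shown sits, means the steps of an at least 3.6-fold higher number from compound 1 to compound 3 (0.56 log units; beyond the scatter) and an at least 7.1-fold higher number from compound 2 to compound 3 (0.85 log units; beyond the scatter) are known only as lower bounds.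

Compound 4 `COc1cc(-c2cccc3nc(-c4ccco4)oc23)cc(OC)c1OC`, not yet measured in this assay, differs from compound 2 at the same place where the three measured compounds differ: furan-2-yl in place of 4-methoxyphenyl on an aromatic carbon. All three measured steps bear on this position. Removing the methoxy cost little, while adding a methyl cost at least a modest amount. Within the data shown here, no measured step covers a five-membered heteroaryl here, so the expectation is uncertain, but a modest rise in the number seems more likely than a fall. Compound 4 is therefore expected to give about 10000 nM in this assay, between 3000 nM and 30000 nM, which would mean the step of a 2.9-fold higher number from compound 2 to compound 4 (0.46 log units; beyond the scatter).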

Compound 4, half-maximal inhibitory concentration: 2600 nM
Beside the measured number, compound 4's estimate is 3.8-fold (0.59 log units) above it, and the stated range ends above it.
By their numbers in this assay, from the lowest: compounds 4, 2 and 1 (each within the scatter of the next, the first and the last beyond it). At a limit, above all of these: compound 3.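

In this assay, furan-2-yl on the aromatic carbon next to the ring nitrogen and the ring oxygen cannot be told apart from 4-methoxyphenyl, with a 1.3-fold lower number from compound 2 to compound 4 (0.13 log units; within the scatter). Set against phenyl, it gives a 2.6-fold lower number from compound 1 to compound 4 (0.42 log units; beyond the scatter), the first replacement of phenyl at this position to lower the number beyond the scatter. The step of an at least 9.6-fold lower number from compound 3 to compound 4 (0.98 log units; beyond the scatter) is known only as a bound, as compound 3 stands at a limit: the limit of > 25000 nM in this assay, at which 1 of the 4 values shown sits.

The compounds shown leave open whether this result is particular to furan-2-yl or extends to other five-membered aromatic rings, such as thiophene or oxazole. They also leave open how a group without an aromatic ring, such as an amine or a short alkyl chain, would fare at this carbon.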